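Hydroxymethyl to carbamoyl on the nitro compound

A few compounds are considered here, and "the series" means these few. Any claim that something is new, unique, unknown or untested is made for them only; others in the source may bear on it.

In a physicochemical assay for solubility, read by HPLC, at pH 7.4 (a higher number here means a more soluble compound, a lower number a less soluble compound), compound 1 (`CCCCCOCc1cc(=O)c2ccccc2[nH]1`) reads > 200000 nM as a limit of the assay and not as a number. Within the data shown here, compound 2 (`CCCCCCCc1[nH]c2ccccc2c(=O)c1CO`) gives 50000 nM and compound 3 (`CCCCCCCc1[nH]c2ccc([N+](=O)[O-])cc2c(=O)c1CO`) gives 5000 nM as the lowest of the two true numbers so far. Among the measured compounds shown here, the single measured step, nitro in place of hydrogen on an aromatic carbon, is a 10-fold lower number from compound 2 to compound 3 (1.00 log units; beyond the scatter) and lies beyond the scatter.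

Compound 4 (`CCCCCCCc1[nH]c2ccc([N+](=O)[O-])cc2c(=O)c1C(N)=O`) differs from compound 3 by carbamoyl in place of hydroxymethyl on an aromatic carbon ortho to a heptyl group. For the measured compounds named here, no measured step exchanges these two groups. The nitro step of a 10-fold lower number from compound 2 to compound 3 (1.00 log units; beyond the scatter) is a different change and serves only as a rough scale for what one substitution has done in this series. It gives no direct direction for the present exchange. In this assay a small shift is therefore expected, most likely within the scatter and leaning towards a lower number. The estimated change is a 1.7-fold lower number from compound 3 to compound 4 (0.22 log units; within the scatter) in the central case. For compound 4 the estimated value is 3000 nM with an expected range from 800 nM to 10000 nM in repeat measurements.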

Compound 4, solubility: 15000 nM
Estimate against measurement, compound 4: 5.0-fold (0.70 log units) below; the whole stated range lies below it.
By their numbers in this assay, from the lowest: compound 3; then compound 4; then compound 2. At a limit, above all of these: compound 1.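

This position now has a measured exchange of its own: in this assay, carbamoyl in place of hydroxymethyl on the aromatic carbon ortho to a heptyl group gives a 3.0-fold higher number from compound 3 to compound 4 (0.48 log units; beyond the scatter). Among these compounds, the only other step, the nitro step, gives a 10-fold lower number from compound 2 to compound 3 (1.00 log units; beyond the scatter), so the new step runs the opposite way, and it is read with nitro present on both of its compounds. The leaving and entering groups carry the same counts of hydrogen-bond donors and acceptors and no net charge, and nothing measured here ties the step to a property of either group.

Going by these compounds, whether the carbamoyl step keeps its direction and size without the nitro group stays open, since it is read only on the nitro compounds. Also open, on these data alone, is how this assay responds to other groups at this aromatic carbon, such as a carboxylic acid or an amine, and to a chain longer than heptyl on the neighbouring position of the shared core.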